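This account rests on a few compounds, and the source may have more. Where it says the series, first, only, none or still open, it means among the compounds named here.

The measured compounds are these. Compound 1 `CCC1(Cc2ccccc2)OS(=O)(=O)C=C1OCC#N` gives > 200000 nM, a limit of the assay. Compound 2 `CC(C)CC1(Cc2ccccc2)OS(=O)(=O)C=C1OCc1ccccc1` gives 102000 nM. Compound 3 `CCC1(Cc2ccccc2)OS(=O)(=O)C=C1OC(c1ccccc1)c1ccccc1` gives > 200000 nM, also a limit.

Among the compounds with values here, in an ADME assay on HEL cells (Homo sapiens) for cytotoxicity, with a stated time of 3 days (on this read-out higher numbers stand for lower toxicity in this test and lower numbers for higher toxicity in this test), compound 2 thus holds the only number of the three, the other two sitting at the limit of > 200000 nM in this assay, at which 2 of the 3 values shown sit. Compound 4 `CCCC1(Cc2ccccc2)OS(=O)(=O)C=C1OCc1ccccc1` differs from compound 2 by hydrogen in place of methyl on a saturated chain carbon bound to two saturated chain carbons. Within the data shown here, no step between measured compounds is available, so nothing about this change is known from the data. A shift no larger than the usual scatter is expected. The change from compound 2 to compound 4 is estimated at a 1.1-fold higher number from compound 2 to compound 4 (0.03 log units; within the scatter). Compound 4 is expected to give 110000 nM, within 45000 nM to 260000 nM.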

Compound 4, half-maximal cytotoxic concentration: 200000 nM
The estimate for compound 4 lay 1.8-fold (0.26 log units) below the measured number; low and high end bracket the measured number.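

In this assay, within the data shown here, going from isobutyl to propyl gives a 2.0-fold higher number from compound 2 to compound 4 (0.29 log units; within the scatter), so the first readable step at this position stays within the usual scatter. Compound 4 gives 200000 nM, a measured number rather than a limit. That number matches the figure of the limit in this test: the limit of > 200000 nM in this assay, at which 2 of the 4 values shown sit.

The compounds shown leave open whether a longer chain, an amine or a carboxylic acid in place of the propyl would move the number beyond the scatter.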